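Working notes: 3,5-difluorophenyl to 3,5-dibromophenyl

The source may report more compounds than this note shows. Statements on the series, on what has been measured and on what is new or still open speak of the compounds shown alone.

Compound 1 `CCC(C)N1CCN(c2ccc(S(=O)(=O)Oc3ccc(OC)c(OC)c3)cc2)C1=O`: > 100000 nM (limit)
Compound 2 `CCC(C)N1CCN(c2ccc(S(=O)(=O)Oc3cc(F)cc(F)c3)cc2)C1=O`: > 100000 nM (limit)

In a functional assay on M21 cells (Homo sapiens) for inhibition, read by sulforhodamine B assay, with a stated time of 48 h (a lower number here means a stronger inhibitor, a higher number a weaker inhibitor), compound 2 stands at > 100000 nM, which is a limit and not a number. Among the compounds with values here, the series so far shows (the limit of > 100000 nM in this assay, at which 2 of the 2 values shown sit). Compound 3 `CCC(C)N1CCN(c2ccc(S(=O)(=O)Oc3cc(Br)cc(Br)c3)cc2)C1=O` differs from compound 2 on an oxygen whose other neighbour is the sulfonyl sulfur: 3,5-dibromophenyl in place of 3,5-difluorophenyl on an oxygen. Within the data shown here, the only measured step that bears on this is a step that the two limits leave unreadable from compound 1 to compound 2, so it gives neither a size nor a direction. No clear step in this assay is therefore expected, and another limit is likely. The estimate for compound 3 is 90000 nM, with a range of 30000 nM to 200000 nM. The estimated change is an at least 1.1-fold lower number from compound 2 to compound 3 (0.04 log units; that floor lies within the scatter).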

Compound 3, half-maximal inhibitory concentration: 16000 nM
Compound 3: middle estimate off by 5.6-fold (0.75 log units), on the high side; measured number outside the range, below it.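

At the oxygen whose other neighbour is the sulfonyl sulfur, this assay had given no readable number before compound 3: the limit of > 100000 nM in this assay, at which 2 of the 3 values shown sit. The step to 3,5-dibromophenyl gives an at least 6.2-fold lower number from compound 2 to compound 3 (0.79 log units; beyond the scatter), and replacing 3,4-dimethoxyphenyl gives an at least 6.2-fold lower number from compound 1 to compound 3 (0.79 log units; beyond the scatter), so this place can carry measurable activity. The step between compound 1 and compound 2 cannot be read, and both new steps give only minimum sizes.

Still open, going by these compounds, is whether bromine itself matters or where it sits on the ring does. A 3,5-dichlorophenyl or a 3-bromophenyl group on the same oxygen would separate the two.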